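The source may hold more compounds than are shown below. What is called first, only, known or untested is meant among the compounds shown, and "the series" means these compounds.

Of the compounds shown here, three have been tested in an ADME assay on cells (Macrophage, Mus musculus) for cytotoxicity, read by resazurin assay, with a stated time of 3 days; on this read-out lower numbers stand for stronger inhibition and higher numbers for weaker inhibition. Compound 1, with the structure `O=C(Nc1ccc(F)c(Cl)c1)c1cc(Cl)ccc1O`, gives 4400 nM in this assay. Compound 2, with the structure `O=C(Nc1ccc(F)c(F)c1)c1cc(Cl)ccc1O`, differs from compound 1 by a single change, (fluoro in place of chloro on an aromatic carbon), and in this assay compound 2 gives 7700 nM; the step of a 1.8-fold higher number from compound 1 to compound 2 (0.24 log units; within the scatter). Compound 3, with the structure `O=C(Nc1cc(C(F)(F)F)ccc1Cl)c1cc(F)ccc1O`, has a different core; how its core differs from the core of compound 1 is not broken down here. In this assay compound 3 gives 6100 nM.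

Compound 4, with the structure `O=C(Nc1cc(C(F)(F)F)ccc1F)c1cc(F)ccc1O`, is not yet measured. It differs from compound 3 by fluoro in place of chloro on an aromatic carbon. Going by the values given here, this is the same kind of change as the one from compound 1 to compound 2, but the surroundings differ: in compound 2 the new group sits ortho to a fluoro group and meta to a large group, whereas in compound 4 it sits ortho to a large group and para to a trifluoromethyl group. Given that the earlier step stayed within the scatter, compound 4 is expected to show a step of a 1.3-fold higher number from compound 3 to compound 4 (0.12 log units; within the scatter) because compound 3 gives 6100 nM. The estimate for compound 4 is therefore 8000 nM, expected to lie between 3500 nM and 18000 nM.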

Compound 4, half-maximal inhibitory concentration: 5100 nM
The estimate for compound 4 lay 1.6-fold (0.20 log units) above the measured number; low and high end bracket the measured number.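

In this assay, putting fluoro in place of chloro gives a 1.2-fold lower number from compound 3 to compound 4 (0.08 log units; within the scatter), so on this core the swap leaves the number within the usual scatter of repeat measurements. Set beside the same swap on the other core, the two steps cannot be told apart: the same change on two cores in this assay, a 1.8-fold higher number (0.24 log units; within the scatter) from compound 1 to compound 2 and a 1.2-fold lower number (0.08 log units; within the scatter) from compound 3 to compound 4, 2.1-fold (0.32 log units) apart, within the scatter of two such steps. This shows that, across these two pairs, the swap carried over from one core to the other without any measurable difference in its outcome, but it does not show that the swap is without effect on every core in the series, and two pairs, each with a step this small, are too few to establish a general rule.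

The compounds shown exchange only chloro and fluoro at this place, so it remains open whether a methyl group, a methoxy group or an amine there would shift the number beyond the scatter. Also open, on these data alone, is whether the swap would behave the same way on a third core or in any other read-out.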